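Side-chain variants on the shared core: compound 4

The source may report more compounds than this note shows. Statements on the series, on what has been measured and on what is new or still open speak of the compounds shown alone.

Measured so far:
- compound 1 `COc1ccc(/C=C\c2cc(OC)c(OC)c(OC)c2)cc1OCc1ccc(C=O)cc1`: 4200 nM
- compound 2 `COc1ccc(/C=C\c2cc(OC)c(OC)c(OC)c2)cc1OCc1ccc(CN2CCCC[C@@H]2C(=O)O)cc1`: > 10000 nM
- compound 3 `COc1ccc(/C=C\c2cc(OC)c(OC)c(OC)c2)cc1OCc1ccc(CO)cc1`: 6600 nM

In a functional assay on B16-F10 cells (Mus musculus) for antiproliferative activity, read by CCK-8 assay, with a stated time of 48 h (a lower number here means a stronger inhibitor, a higher number a weaker inhibitor), compound 1 gives 4200 nM and compound 3 gives 6600 nM. Compound 2 returns only a limit, > 10000 nM, so its true number is not known (the limit of > 10000 nM in this assay, at which 1 of the 3 values shown sits). The steps to it are therefore bounded rather than measured: an at least 2.3-fold higher number from compound 1 to compound 2 (0.37 log units; beyond the scatter), and an at least 1.5-fold lower number from compound 2 to compound 3 (0.18 log units; that floor lies within the scatter). Between the two numbered compounds the step is small, a 1.6-fold higher number from compound 1 to compound 3 (0.20 log units; within the scatter).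

Compound 4 `COc1ccc(/C=C\c2cc(OC)c(OC)c(OC)c2)cc1OCc1ccc(CNCCNC(C)=O)cc1` differs from compound 2 as follows: (2-acetamidoethyl)amino in place of 2-carboxypiperidin-1-yl on a saturated chain carbon bound to an aromatic carbon. Both of the steps involving compound 2 point the same way, with the 2-carboxypiperidin-1-yl bearer sitting at the limit while formyl and hydroxymethyl bearers sit at measurable numbers. The entering (2-acetamidoethyl)amino is a different chain, so a number off the limit is expected but not assured; the estimate for compound 4 is 7000 nM, range 3000 nM to 15000 nM, which is expected to amount to an at least 1.4-fold lower number from compound 2 to compound 4 (0.15 log units; that floor lies within the scatter).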

Compound 4, half-maximal inhibitory concentration: 2500 nM
Beside the measured number, compound 4's estimate is 2.8-fold (0.45 log units) above it, outside the stated range (below it).
By their numbers in this assay, from the lowest: compounds 4, 1 and 3 (each within the scatter of the next, the first and the last beyond it). At a limit, above all of these: compound 2.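

Exchanging 2-carboxypiperidin-1-yl for (2-acetamidoethyl)amino on this saturated chain carbon bound to an aromatic carbon gives an at least 4.0-fold lower number from compound 2 to compound 4 (0.60 log units; beyond the scatter), and the size of that step is only a floor. Compound 2 holds a limit, not a number: the limit of > 10000 nM in this assay, at which 1 of the 4 values shown sits.

Against hydroxy, the same chain gives a 2.6-fold lower number from compound 3 to compound 4 (0.42 log units; beyond the scatter), the only step in this set with a measured number at both ends that lies beyond the scatter, whereas the exchange for formyl gives a 1.7-fold lower number from compound 1 to compound 4 (0.23 log units; within the scatter), which does not separate compound 1 from compound 4.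

The compounds shown do not separate the contribution of the amino nitrogen from that of the acetamido end of the chain, and a plain ethylamino group would bear on this. On these data alone, whether a piperidin-1-yl group without the carboxylic acid would leave the limit also stays open.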